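This account rests on a few compounds, and the source may have more. Where it says the series, first, only, none or still open, it means among the compounds named here.

Measured so far in a functional assay on the whole organism (strain albino) for inhibition, with Rattus norvegicus as the target, read by paw edema, with stated times of 30 min and 2 h, at a dose of 0.28 mmol/kg by the oral route; a higher number here means more inhibition at the dose given (going by the name of the read-out), a lower number less inhibition:
compound 1 `CCn1c(SCC(=O)Nc2ccc(C(C)=O)cc2)nnc1-c1ccc(OC)cc1` gives 54%
compound 2 `C=CCn1c(SCC(=O)Nc2ccc(C(C)=O)cc2)nnc1-c1ccc(OC)cc1` gives 51%

Compound 2 and compound 1 are separated only by a number 3 percentage points lower from compound 1 to compound 2 (within the scatter), a gap within the scatter, so the two cannot be told apart on these numbers. Compound 3 `COc1ccc(-c2nnc(SCC(=O)Nc3ccc(C(C)=O)cc3)n2-c2ccccc2)cc1` differs from compound 2 by phenyl in place of allyl on an aromatic nitrogen. Among the compounds with values here, the one measured step, a number 3 percentage points lower from compound 1 to compound 2 (within the scatter), also varies the group held at the aromatic nitrogen of the shared core and moves nothing beyond the scatter; no measured step puts an aromatic group at that place. A step of a number 1 percentage points lower from compound 2 to compound 3 (within the scatter) in this assay is therefore expected for compound 3, none beyond the scatter. Compound 3 is estimated at 50%, range 35% to 65%.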

Compound 3, a percentage reported as inhibition, in the whole organism at one dose (the size of the read-out at that dose, not a potency): 42%
Beside the measured number, compound 3's estimate is 8 percentage points above it, within the range that was stated.
By their numbers in this assay, from the lowest: compounds 3, 2 and 1 (each within the scatter of the next, the first and the last beyond it).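

Within the data shown here, at the aromatic nitrogen of the shared core, an aromatic group now enters: in this assay phenyl gives a number 12 percentage points lower from compound 1 to compound 3 (beyond the scatter) in place of ethyl, the only step at this position beyond the scatter, and a modest one. In place of allyl it gives a number 9 percentage points lower from compound 2 to compound 3 (within the scatter), so compound 3 cannot be told apart from compound 2. No measurement on hand bears on the origin of either step. Open, from the compounds shown here alone, is whether a benzyl group or a longer chain at this nitrogen would read with ethyl or with phenyl.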